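A few compounds are considered here, and "the series" means these few. Any claim that something is new, unique, unknown or untested is made for them only; others in the source may bear on it.

Compound 1 `CC(=O)N1CCC(c2ccc(-c3cc(C(=O)O)cc4cc(-c5ccc(C(F)(F)F)cc5)ccc34)cc2)CC1` is the reference point of this set. In a functional assay on the whole organism (strain ICR) for inhibition, with Mus musculus as the target, with stated times of 7 days and 0.5 h, at a dose of 10 umol/kg by the intraperitoneal route (on this read-out higher numbers stand for more inhibition at the one dose given (going by the name of the read-out) and lower numbers for less inhibition), compound 1 gives 83.3%. Compound 2 `O=C(O)c1cc(-c2ccc(C3CCNCC3)cc2)cc(-c2cn(-c3ccc(C(F)(F)F)cc3)nn2)c1` gives 70.7% and compound 3 `O=C(O)c1cc(-c2ccc(C3CCNCC3)cc2)cc(-n2cc(-c3ccc(C(F)(F)F)cc3)nn2)c1` gives 52.4%, so compound 1 stands highest of the three, with both gaps beyond the usual scatter. Compound 4 `CCC(=O)N1CCC(c2ccc(-c3cc(C(=O)O)cc4cc(-c5ccc(C(F)(F)F)cc5)ccc34)cc2)CC1` has not yet been measured. It differs from compound 1 in one place: methyl in place of hydrogen on a saturated chain carbon bound to a carbonyl carbon. Among the measured compounds shown here, the three measured compounds differ from one another in several places at once, so no single-change step is available to calibrate an acetyl to propanoyl change. On the estimate made here, a number 3.3 percentage points lower from compound 1 to compound 4 (within the scatter) is expected to be small and in neither direction beyond the scatter. Compound 4 is therefore estimated at 80%, with a range from 65% to 92%.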

Compound 4, a percentage reported as inhibition, in the whole organism at one dose (the size of the read-out at that dose, not a potency): 32.9%
Beside the measured number, compound 4's estimate is 47.1 percentage points above it, and the stated range ends above it.
By their numbers in this assay, from the lowest: compound 4; then compound 3; then compound 2; then compound 1.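

In this assay, going from acetyl to propanoyl brings a number 50.4 percentage points lower from compound 1 to compound 4 (beyond the scatter). Among the compounds shown here, this is the only single-change step in the set, and it shows that the read-out at this dose is highly sensitive to 1 added carbon at this position on the shared core. Nothing available bears on why so small a change has so large an effect.

The compounds shown leave open whether a longer chain such as butanoyl, or a branched one such as isobutyryl, would lower the number further or restore it.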